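Permeability after swapping pyrazolyl for hydroxycyclopropyl

A few compounds are considered here, and "the series" means these few. Any claim that something is new, unique, unknown or untested is made for them only; others in the source may bear on it.

Measured in an ADME assay on MDCK cells (Canis lupus familiaris) for permeability, in the apical to basolateral direction; a lower number here means that the compound crosses the layer more slowly, a higher number that the compound crosses the layer faster:
- Compound 1 `CC(C)(C)C(=O)Nc1sc(S(=O)(=O)c2ccc(F)cc2)cc1C(N)=O`: "not determined" (no result reported)
- Compound 2 `CC(C)(O)C(=O)Nc1sc(S(=O)(=O)c2ccc(F)cc2)cc1C(N)=O`: 4 10^-6 cm/s
- Compound 3 `NC(=O)c1cc(S(=O)(=O)c2ccc(F)cc2)sc1NC(=O)c1ccn[nH]1`: 0.9 10^-6 cm/s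

Of the two compounds with a number, compound 3 stands lowest, at 0.9 10^-6 cm/s. For the measured compounds named here, the one measured step that bears on the next change is a 4.4-fold lower number from compound 2 to compound 3 (0.65 log units; beyond the scatter). Compound 4 `NC(=O)c1cc(S(=O)(=O)c2ccc(F)cc2)sc1NC(=O)C1(O)CC1` differs from compound 3 as follows: 1-hydroxycyclopropyl in place of 1H-pyrazol-5-yl on a carbonyl carbon. This removes the same 1H-pyrazol-5-yl, and the entering 1-hydroxycyclopropyl resembles the 1-hydroxy-1-methylethyl of compound 2, which gives 4 10^-6 cm/s. Most of that measured step is therefore expected to be reversed, towards a higher number in this assay. The estimated step is a 3.3-fold higher number from compound 3 to compound 4 (0.52 log units; beyond the scatter). For compound 4 the expected value is 3 10^-6 cm/s, with an estimated range of 1.2 10^-6 cm/s to 7 10^-6 cm/s.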

Compound 4, apparent permeability: 1 10^-6 cm/s
Beside the measured number, compound 4's estimate is 3.0-fold (0.48 log units) above it; measured number below the stated range.
By their numbers in this assay, from the lowest: compounds 3 and 4 (each within the scatter of the next); then compound 2.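

In this assay, 1-hydroxycyclopropyl in place of 1H-pyrazol-5-yl on the carbonyl carbon gives a 1.1-fold higher number from compound 3 to compound 4 (0.05 log units; within the scatter) and so leaves the number where it stood. Against compound 2, the change to 1-hydroxycyclopropyl gives a 4.0-fold lower number from compound 2 to compound 4 (0.60 log units; beyond the scatter) and shows that at this position these two hydroxyl-bearing groups do not read alike. Nothing shown gives a reason for this difference. The compounds shown leave open how a 1-aminocyclopropyl or 1-methoxycyclopropyl group on the same carbonyl carbon would read in this assay and whether either would come closer to compound 2.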